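Trimming One Methoxy Group from a Weak Glucosidase Inhibitor

The compounds below may be only part of what the source reports. "The series", "measured", "known", "first", "only" and "open" are said of these compounds alone.

Compound 1 `C[C@]1(CO)NC[C@@H](O)[C@@H]1O` gives 830 nM
Compound 2 `COc1cccc([C@]2(CO)NC[C@@H](O)[C@@H]2O)c1` gives 52000 nM
Compound 3 `COc1ccc([C@@]2(CO)NC[C@H](O)[C@H]2O)cc1OC` gives 60000 nM

These three compounds share a small core carrying a hydroxymethyl arm and two hydroxyl groups, and were tested in an assay on isolated protein for inhibition of lysosomal alpha-glucosidase (Rattus norvegicus), read by colorimetric assay; on this read-out lower numbers stand for stronger inhibition and higher numbers for weaker inhibition. Compound 1, which carries only a methyl group on that core, gives 830 nM. The two compounds in which an aromatic ring replaces the methyl show far weaker inhibition: compound 2 gives 52000 nM, and compound 3 gives 60000 nM. Compound 3 has the highest number of the three, but its gap to compound 2 is within the usual scatter, so the two cannot be told apart; only the gap to compound 1 is clearly beyond the scatter.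

The next compound, compound 4 `COc1cccc([C@@]2(CO)NC[C@H](O)[C@H]2O)c1`, is obtained from compound 3 by a single change: hydrogen in place of methoxy on an aromatic carbon. For the measured compounds named here, no measured pair shows this exact change, so its effect is unknown. Since compound 2 and compound 3 sit so close together despite differing in their aromatic substitution, compound 4 is expected to stay in the same weak region, with a step of a 1.2-fold lower number from compound 3 to compound 4 (0.08 log units; within the scatter) that is expected to remain within the scatter. The estimate for compound 4 in this assay is 50000 nM, expected to fall between 15000 nM and 160000 nM.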

Compound 4, half-maximal inhibitory concentration: 108000 nM
Compound 4: middle estimate off by 2.2-fold (0.33 log units), on the low side, and the stated range covers the measured number.
By their numbers in this assay, from the lowest: compound 1; then compounds 2, 3 and 4 (each within the scatter of the next, the first and the last beyond it).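

Taking the methoxy group off the aromatic ring, at the carbon ortho to a methoxy group and para to a group of 9 heavy atoms, gives a 1.8-fold higher number from compound 3 to compound 4 (0.26 log units; within the scatter), so in this assay this change cannot be told apart from no change at all. For the compounds shown here, the new compound also provides the first pair of mirror images in the set, and a 2.1-fold higher number from compound 2 to compound 4 (0.32 log units; beyond the scatter) shows that inverting every stereocentre has a modest effect, only just past the scatter, in this aromatic series. That gap can be assigned to configuration alone, because no other difference exists within the pair: the fact that compounds 2 and 4 differ only in the configuration as drawn

The compounds shown leave open whether a different group at this aromatic carbon, such as an amine or a carboxylic acid, would give a number that can be told apart from those with methoxy or hydrogen. Also open, from the compounds shown here alone, is how far inverting all the stereocentres would shift the number for compound 1, whose methyl group stands where the other compounds carry an aromatic ring.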